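Carboxy for vinyl on a compound at the assay limit

A few compounds are considered here, and "the series" means these few. Any claim that something is new, unique, unknown or untested is made for them only; others in the source may bear on it.

Compound 3 `C=CCN(C)C(=O)c1ccc(C(CC)(CC)c2ccc(OCC(O)C(C)(C)C)c(C)c2)n1CC` gives > 50000 nM in a functional assay on HepG2 cells (Homo sapiens), read by MTT assay, with a stated time of 48 h (on this read-out lower numbers stand for stronger inhibition and higher numbers for weaker inhibition), which is a limit of the assay and not a number. Compound 4 `CCn1c(C(=O)N(C)CC(=O)O)ccc1C(CC)(CC)c1ccc(OCC(O)C(C)(C)C)c(C)c1` differs from it by carboxy in place of vinyl on a saturated chain carbon bound to an amide-type nitrogen. Among the measured compounds shown here, no measured step touches this change directly, so the nearest evidence comes from the two amino chains on the carbonyl carbon. Compound 1 `CCn1c(C(=O)NCCCN(C)C)ccc1C(CC)(CC)c1ccc(OCC(O)C(C)(C)C)c(C)c1` gives 360 nM in this assay. Compound 2 `CCN(CC)CCCNC(=O)c1ccc(C(CC)(CC)c2ccc(OCC(O)C(C)(C)C)c(C)c2)n1CC` gives 1100 nM there, a modest difference, a 3.1-fold higher number from compound 1 to compound 2 (0.49 log units; beyond the scatter). Replacing either chain with allyl(methyl)amino produced a large loss, an at least 130-fold higher number from compound 1 to compound 3 (2.14 log units; beyond the scatter) and an at least 45-fold higher number from compound 2 to compound 3 (1.65 log units; beyond the scatter). In compound 4 the carbonyl carbon carries (carboxymethyl)(methyl)amino, so neither the (3-(dimethylamino)propyl)amino nor the (3-(diethylamino)propyl)amino chain returns. Given an at least 130-fold higher number from compound 1 to compound 3 (2.14 log units; beyond the scatter), no recovery is expected, and no step beyond the scatter is anticipated in this assay. The estimate therefore amounts to an expected a number no higher from compound 3 to compound 4 (the limit leaves the size open). For compound 4 the expected value is 50000 nM, with an estimated range of 15000 nM to 150000 nM.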

Compound 4, half-maximal inhibitory concentration: 17100 nM
Beside the measured number, compound 4's estimate is 2.9-fold (0.47 log units) above it; the measured number falls inside the stated range.
By their numbers in this assay, from the lowest: compound 1; then compound 2; then compound 4. At a limit, above all of these: compound 3.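

In this assay compound 3 gives a limit and not a number: the limit of > 50000 nM in this assay, at which 1 of the 4 values shown sits. Carboxy in place of vinyl on a saturated chain carbon bound to an amide-type nitrogen brings the reading within the assay's range, an at least 2.9-fold lower number from compound 3 to compound 4 (0.46 log units; beyond the scatter) and so shows that a carbonyl carbon without either amino chain need not end at the limit. The recovery is only partial, however, with a 16-fold higher number from compound 2 to compound 4 (1.19 log units; beyond the scatter) and a 48-fold higher number from compound 1 to compound 4 (1.68 log units; beyond the scatter); among the compounds shown, the two carrying the (3-(dimethylamino)propyl)amino and (3-(diethylamino)propyl)amino chains remain the ones with the lowest numbers, and (carboxymethyl)(methyl)amino does not stand in for them.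

On these data alone, it remains open whether the gain is specific to the carboxy group, as a methyl ester, a primary amide or a hydroxyl at the same place could give a different number. Also open, as far as these compounds go, is how the reading would respond to a longer chain before the carboxylic acid, or to a primary amine or a morpholine at the end of the propyl chain of compound 1.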